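The compounds below may be only part of what the source reports. "The series", "measured", "known", "first", "only" and "open" are said of these compounds alone.

Of the compounds shown here, three built on the shared core have so far been measured in a functional assay on MDA-MB-436 cells (Homo sapiens) for antiproliferative activity, read by MTT assay, with a stated time of 48 h (a higher number here means a weaker inhibitor, a lower number a stronger inhibitor), and give a first sense of the range. Compound 1 `C=CS(=O)(=O)N1CCN(c2ncnc3sc(-c4cn(S(=O)(=O)c5ccccc5)c5ccccc45)cc23)CC1` gives 38000 nM in this test, and compound 2 `C=CS(=O)(=O)N1CCN(c2ncnc3sc(-c4ccc(N5CCN(C)CC5)cc4)cc23)[C@@H](C)C1` gives 6920 nM there. Compound 3 `CN1CCN(c2ccc(-c3cc4c(N5CCN(S(=O)(=O)/C=C/c6ccccc6)CC5)ncnc4s3)cc2)CC1` gives 8670 nM and so stands in the middle of the three numbers. Its value lies within the usual scatter of compound 2, so those two cannot be ranked. Its number is clearly lower than that of compound 1, which marks it as the stronger inhibitor of that pair.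

Compound 4 `CN1CCN(c2ccc(-c3cc4c(N5CCN(C(=O)Nc6ccc(Cl)cc6)CC5)ncnc4s3)cc2)CC1` is the next case. It has (4-chlorophenyl)carbamoyl in place of (2-phenylethenyl)sulfonyl on an amine nitrogen in a ring and keeps the rest of compound 3 unchanged. Within the data shown here, no two measured compounds differ in only one place, so the effect of such a swap has not been seen directly, and the direction is a tentative call. A modest step toward a lower number in this assay is expected, not far beyond the scatter. In numbers, the estimated change is a 1.7-fold lower number from compound 3 to compound 4 (0.24 log units; within the scatter) and carries wide uncertainty. For compound 4 the expected value is 5000 nM with an estimated range from 1500 nM to 16000 nM in this test.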

Compound 4, half-maximal inhibitory concentration: 9270 nM
Estimate against measurement, compound 4: 1.9-fold (0.27 log units) below; measured number inside the range.
By their numbers in this assay, from the lowest: compounds 2, 3 and 4 (each within the scatter of the next); then compound 1.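

Among these compounds, this is the first pair in the set that differs in only one place, so it gives the first direct reading of a change on the amine nitrogen in the ring. In this assay, putting (4-chlorophenyl)carbamoyl in place of (2-phenylethenyl)sulfonyl gives a 1.1-fold higher number from compound 3 to compound 4 (0.03 log units; within the scatter), so the two compounds cannot be ranked, even though the groups differ in their linking atoms and in their counts of hydrogen-bond donors and acceptors. For this one pair, those differences leave no readable mark on the number, but nothing measured here explains that result.

A single swap cannot show whether this nitrogen tolerates substitution in general, and a small acetyl or methyl group, or the free ring amine carrying only hydrogen, could still read quite differently from these two large groups. Going by these compounds, the role of the chlorine also remains open, since a carbamoyl group bearing an unsubstituted phenyl ring or a 4-methoxyphenyl ring would be needed to separate the effect of that atom from the effect of the rest of the group.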